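The compounds below may be only part of what the source reports. "The series", "measured", "known", "first", "only" and "open" are said of these compounds alone.

Working notes on the series in an assay on CHO cells with metabotropic glutamate receptor 5 (Homo sapiens) as the target; on this read-out higher numbers stand for an effect only at larger amounts of compound and lower numbers for an effect already at smaller amounts. Compound 1 `O=C(Nc1cc(-c2ccccc2)nn1-c1ccccc1)c1cccc(Cl)c1` gives 40 nM and compound 2 `O=C(Nc1cc(-c2ccccc2)nn1-c1ccccc1)c1cccc(F)c1` gives 20 nM; between them lies a 2.0-fold lower number from compound 1 to compound 2 (0.30 log units; within the scatter). Compound 3 `O=C(Nc1cc(-c2ccccc2)nn1-c1ccccc1)c1ccccc1O` reaches only a limit of this assay, > 10000 nM, so its position is a bound and not a number. It sits at the limit of > 10000 nM in this assay, at which 1 of the 3 values shown sits.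

The next compound, compound 4 `Cc1ccccc1C(=O)Nc1cc(-c2ccccc2)nn1-c1ccccc1`, differs from compound 3 by methyl in place of hydroxy on an aromatic carbon. Among the compounds with values here, the steps that bear on this are an at least 250-fold higher number from compound 1 to compound 3 (2.39 log units; beyond the scatter) and an at least 500-fold higher number from compound 2 to compound 3 (2.69 log units; beyond the scatter); both run into the limit, so how far the removal of the hydroxy reverses them is open. The step expected in this assay is an at least 20-fold lower number from compound 3 to compound 4 (1.30 log units; beyond the scatter), downward and beyond the scatter, with wide uncertainty. Compound 4 is therefore estimated at 500 nM, within 40 nM to 10000 nM.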

Compound 4, half-maximal effective concentration: > 10000 nM
Compound 4: only a limit was reported; the forecaster's own chance of this, stated with the estimate: 30%; at least 20-fold (1.30 log units) between middle value and limit.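

Like compound 3, compound 4 reaches only a limit in this assay, > 10000 nM. With methyl in place of hydroxy on the same aromatic carbon, ortho to a large group, the loss is therefore not confined to the hydroxy compound: 2-methylphenyl in place of 3-fluorophenyl gives an at least 500-fold higher number from compound 2 to compound 4 (2.69 log units; beyond the scatter), and in place of 3-chlorophenyl gives an at least 250-fold higher number from compound 1 to compound 4 (2.39 log units; beyond the scatter). The step from compound 3 to compound 4 cannot be read, as both sit at one limit: the limit of > 10000 nM in this assay, at which 2 of the 4 values shown sit.

From the compounds shown here alone, whether the position or the particular groups decide the outcome remains open. A 3-methylphenyl, 3-hydroxyphenyl or 2-fluorophenyl amide would separate the two, and an amine at either position is also untested in the compounds shown.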